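The compounds below may be only part of what the source reports. "The series", "measured", "known", "first", "only" and "open" are said of these compounds alone.

Measured so far in a functional assay on cells for positive allosteric modulation of metabotropic glutamate receptor 2 (Homo sapiens), read by fluorescence and calcium flux, with a stated time of 30 min; a higher number here means that more compound is needed for the effect, a lower number that less compound is needed:

compound 1 `Brc1cccc2c1nnn2CC1CC1`: 70 nM
compound 2 `CC(C)Cn1nnc2c(Br)cccc21`: 140 nM

Compound 2 stands at 140 nM in this assay, separated from compound 1 only by the step of a 2.0-fold higher number from compound 1 to compound 2 (0.30 log units; within the scatter), which lies within the scatter. Compound 3 `CCCCn1nnc2c(Br)cccc21` differs from compound 2 by propyl in place of isopropyl on a saturated chain carbon bound to an aromatic nitrogen. Within the data shown here, the one measured step at this position, a 2.0-fold higher number from compound 1 to compound 2 (0.30 log units; within the scatter), stayed within the scatter, so no step beyond the scatter is expected in this assay from this change either. Compound 3 is therefore estimated at 140 nM, with a range from 55 nM to 350 nM. For compound 3 this estimate means an expected step of no change at the digits printed from compound 2 to compound 3 (within the scatter).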

Compound 3, half-maximal effective concentration: 60 nM
The estimate for compound 3 lay 2.3-fold (0.37 log units) above the measured number; low and high end bracket the measured number.
By their numbers in this assay, from the lowest: compounds 3, 1 and 2 (each within the scatter of the next, the first and the last beyond it).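

In this assay, among these compounds, joining the same carbons as propyl rather than isopropyl gives the first step beyond the scatter at this position, though a modest one (a 2.3-fold lower number from compound 2 to compound 3 (0.37 log units; beyond the scatter)). Propyl in place of cyclopropyl, by contrast, stays within the scatter (a 1.2-fold lower number from compound 1 to compound 3 (0.07 log units; within the scatter)), so branching alone does not set the numbers apart across these compounds, as compound 1 and compound 2 also lie within the scatter of each other. Nothing available explains the step from isopropyl to propyl.

On these data alone, what a longer chain or a chain carrying an amine would do at this position remains open.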